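A few compounds are considered here, and "the series" means these few. Any claim that something is new, unique, unknown or untested is made for them only; others in the source may bear on it.

Two compounds carry numbers in an assay on HEK293 cells for inhibition of Voltage-dependent T-type calcium channel subunit alpha-1G (Homo sapiens); on this read-out higher numbers stand for weaker inhibition and lower numbers for stronger inhibition. Compound 1 `CC(C)(C)OC(=O)NCCCCCN1C(Nc2ccc(-c3ccccc3)cc2)=Nc2ccccc2C1CC(=O)NCc1ccccc1` gives 170 nM in this assay, and compound 2 `O=C(CC1c2ccccc2N=C(N2CCCCC2)N1c1ccccc1)NCc1ccc(NS(=O)(=O)c2ccc(F)cc2)cc1` gives 110 nM in this assay. Compound 2 holds the lower of the two numbers, yet its gap to compound 1 lies within the scatter, so the two cannot be ordered on this read-out. Compound 3 `O=C(CC1c2ccccc2N=C(N2CCCCC2)N1c1ccccc1)NCc1ccccc1` differs from compound 2 by hydrogen in place of ((4-fluorophenyl)sulfonyl)amino on an aromatic carbon, in words hydrogen in place of ((4-fluorophenyl)sulfonyl)amino on an aromatic carbon. Among the compounds with values here, no step between measured compounds is available to guide this change, so its size must be estimated without precedent. The change strips a sizable fragment from compound 2, and a moderate rise in the number is expected, one that may still end up inside the scatter. For compound 3 the expected value in this assay is 300 nM, with a range from 100 nM to 900 nM. The expected step is a 2.7-fold higher number from compound 2 to compound 3 (0.44 log units; beyond the scatter).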

Compound 3, half-maximal inhibitory concentration: 1160 nM
Compound 3: middle estimate off by 3.9-fold (0.59 log units), on the low side; measured number outside the range, above it.
By their numbers in this assay, from the lowest: compounds 2 and 1 (each within the scatter of the next); then compound 3.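

In this assay, replacing the ((4-fluorophenyl)sulfonyl)amino group with hydrogen gives an 11-fold higher number from compound 2 to compound 3 (1.02 log units; beyond the scatter), a large step beyond the scatter. Within the data shown here, this is the first comparison here of compounds that differ in one place, and it shows that the number depends strongly on what sits at this aromatic carbon, para to a large group. No measurement shown here accounts for the size of this step.

On these data alone, it remains open whether the whole fragment is needed, or whether a simple amine, a methylsulfonylamino group or a phenylsulfonylamino group without the fluorine would keep the number near that of compound 2. The compounds shown also leave open whether the same replacement would give a step of similar size with a different group in place of the piperidine.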